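The compounds below may be only part of what the source reports. "The series", "measured", "known", "first", "only" and "open" are said of these compounds alone.

Measured in an ADME assay on cells (Splenocyte, Mus musculus, strain BALB/c) for cytotoxicity, read by thymidine incorporation, with a stated time of 24 h; on this read-out higher numbers stand for weaker inhibition and lower numbers for stronger inhibition:
Compound 1 `COc1cc(/C=N/NC(=O)CCN2CCN(c3ccnc4cc(Cl)ccc34)CC2)ccc1O` gives 9400 nM.
Compound 2 `COc1cc(/C=N/NC(=O)CCN2CCN(c3ccnc4cc(Cl)ccc34)CC2)ccc1OC(C)=O` gives 15800 nM.
Compound 3 `O=C(CCN1CCN(c2ccnc3cc(Cl)ccc23)CC1)N/N=C/c1c[nH]c2ccccc12` gives 5700 nM.

Compound 3 holds the lowest of these three numbers, yet its gap to compound 1 is within the scatter, a 1.6-fold lower number from compound 1 to compound 3 (0.22 log units; within the scatter), and only the gap to compound 2 is beyond it, a 2.8-fold lower number from compound 2 to compound 3 (0.44 log units; beyond the scatter). Compound 4 `CN(C)c1ccc(/C=N/NC(=O)CCN2CCN(c3ccnc4cc(Cl)ccc34)CC2)cc1` differs from compound 3 at the group on the carbon with a double bond to nitrogen: 4-(dimethylamino)phenyl in place of 1H-indol-3-yl on a carbon with a double bond to nitrogen. Going by the values given here, both measured steps touching that position swap one aromatic group for another and shift the number modestly at most, and no measured compound carries the 4-(dimethylamino)phenyl group. The step in this assay is therefore expected to be small, if any: a 1.2-fold higher number from compound 3 to compound 4 (0.09 log units; within the scatter). Compound 4 is expected to give about 7000 nM, between 3000 nM and 16000 nM.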

Compound 4, half-maximal inhibitory concentration: > 100000 nM
Compound 4 was reported as a limit; the forecaster's own chance of this, stated with the estimate: 5%; middle value at least 14-fold (1.15 log units) from the limit.
By their numbers in this assay, from the lowest: compounds 3, 1 and 2 (each within the scatter of the next, the first and the last beyond it). At a limit, above all of these: compound 4.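

Until now, trading one aromatic group for another at this position had moved the number modestly at most, but 4-(dimethylamino)phenyl in place of 1H-indol-3-yl gives an at least 17-fold higher number from compound 3 to compound 4 (1.24 log units; beyond the scatter). The steps from the other two groups point the same way, toward weaker inhibition: an at least 10-fold higher number from compound 1 to compound 4 (1.02 log units; beyond the scatter) and an at least 6.3-fold higher number from compound 2 to compound 4 (0.80 log units; beyond the scatter). The value of compound 4 is a limit, not a number: the limit of > 100000 nM in this assay, at which 1 of the 4 values shown sits.

The compounds shown leave open whether the dimethylamino group itself accounts for this jump. A plain phenyl or a 4-aminophenyl on the same carbon would help separate the two.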